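The source may hold more compounds than are shown below. What is called first, only, known or untested is meant among the compounds shown, and "the series" means these compounds.

Measured compounds:
compound 1 `CN1CCN(CCNCc2cn(-c3ccc(C(F)(F)F)cc3)nc2-c2ccc(OC(F)(F)F)cc2)CC1` gives 3000 nM in an ADME assay on Huh-7 cells (Homo sapiens) for cytotoxicity; a lower number here means that less compound is tolerated, a higher number that more compound is tolerated
compound 2 `Cc1ccccc1-c1nn(-c2ccc(F)c(F)c2)cc1CNCCN1CCN(C)CC1` gives > 20000 nM in this assay

Compound 2 stands at the edge of what this assay can report. In this assay compound 2 gives > 20000 nM, which is a limit of the assay and not a number (the limit of > 20000 nM in this assay, at which 1 of the 2 values shown sits), so where compound 2 truly sits is known only on one side. Going by the values given here, compound 1 gives 3000 nM in this assay, and is the only one of the pair with a definite value.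

Compound 3 `Cc1ccccc1-c1nn(-c2cccc(Cl)c2)cc1CNCCN1CCN(C)CC1` is not yet measured. It differs from compound 2 in one place (3-chlorophenyl in place of 3,4-difluorophenyl on an aromatic nitrogen).

Among the compounds with values here, no step between measured compounds is available to guide this change, and compound 1 differs from compound 2 in several places at once, so its value says nothing about this single change. The expectation is therefore a step of no size beyond the usual scatter from compound 2 to compound 3, in either direction, with a good chance that the assay again reports only a limit.

On that basis compound 3 is estimated at 18000 nM, between 7000 nM and 40000 nM, which is an expected step of an at least 1.1-fold lower number from compound 2 to compound 3 (0.04 log units; that floor lies within the scatter).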

Compound 3, half-maximal cytotoxic concentration: 16000 nM
Compound 3: the middle estimate sits 1.1-fold (0.05 log units) above what was measured, and the stated range covers the measured number.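

Replacing 3,4-difluorophenyl with 3-chlorophenyl on the aromatic nitrogen gives an at least 1.2-fold lower number from compound 2 to compound 3 (0.09 log units; that floor lies within the scatter) in this assay, and this is the only single change at this position that can be read among the compounds shown. Going by these compounds alone, compound 3 gives a definite value of 16000 nM, so the series carrying the 2-methylphenyl group now has a real number in this assay, and a chlorine-bearing phenyl at this position still leaves that number far from the only value seen for a compound with several changes. The value of compound 2 is a limit and not a number, so the step gives only a floor and its true size stays open on one side: the limit of > 20000 nM in this assay, at which 1 of the 3 values shown sits.

The compounds shown leave open what plain phenyl, 4-chlorophenyl or 3,4-dichlorophenyl on the same nitrogen would give in this assay, and so whether the chlorine or its place on the ring matters at all. They also leave open whether this change would read the same with a group other than 2-methylphenyl on the five-membered ring, such as a plain phenyl or a 4-methoxyphenyl.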